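A Nitro Group in Place of Fluoro

This account rests on a few compounds, and the source may have more. Where it says the series, first, only, none or still open, it means among the compounds named here.

Measured in a functional assay on MCF7 cells (Homo sapiens) for inhibition, read by MTT assay; on this read-out higher numbers stand for weaker inhibition of growth and lower numbers for stronger inhibition of growth:
- compound 1 `COc1cc2oc(-c3cccc(NC(=O)c4ccccc4)c3)cc(=O)c2c(OC)c1OC`: 12100 nM
- compound 2 `COc1cc2oc(-c3cccc(NC(=O)c4ccc(Cl)cc4)c3)cc(=O)c2c(OC)c1OC`: 8780 nM
- compound 3 `COc1cc2oc(-c3cccc(NC(=O)c4ccc(F)cc4)c3)cc(=O)c2c(OC)c1OC`: 14700 nM

The three compounds share one core and differ only in a single aromatic substituent. In this assay, compound 3 gives 14700 nM, which cannot be separated from the other two values. Its nearest neighbour is compound 1, and the step there is a 1.2-fold higher number from compound 1 to compound 3 (0.08 log units; within the scatter). Its furthest is compound 2, and that step is a 1.7-fold higher number from compound 2 to compound 3 (0.22 log units; within the scatter).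

The next compound is compound 4 `COc1cc2oc(-c3cccc(NC(=O)c4ccc([N+](=O)[O-])cc4)c3)cc(=O)c2c(OC)c1OC`, which has nitro in place of fluoro on an aromatic carbon, para to a large group: nitro in place of fluoro on an aromatic carbon.

Going by the values given here, three measured steps bear on this change. Placing chloro on the ring gives a 1.4-fold lower number from compound 1 to compound 2 (0.14 log units; within the scatter), and placing fluoro there gives a 1.2-fold higher number from compound 1 to compound 3 (0.08 log units; within the scatter). Neither step, nor the exchange between the two halogens, leaves the scatter. Among the compounds with values here, no measured compound carries a nitro group, however, so the range has to stay wide. No step beyond the scatter is therefore expected, in either direction. The expected step is a 1.3-fold lower number from compound 3 to compound 4 (0.13 log units; within the scatter).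

For compound 4 the estimated value is 11000 nM, with an expected range from 4500 nM to 27000 nM.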

Compound 4, concentration for 50% growth inhibition: 20100 nM
The estimate for compound 4 lay 1.8-fold (0.26 log units) below the measured number; the range from low to high includes it.
By their numbers in this assay, from the lowest: compounds 2, 1, 3 and 4 (each within the scatter of the next, the first and the last beyond it).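

In this assay, going by these compounds alone, the nitro group gives the first step at this position that leaves the scatter, though only modestly (a 2.3-fold higher number from compound 2 to compound 4 (0.36 log units; beyond the scatter)), whereas no exchange among the first three compounds did so. The other two steps stay within the scatter (a 1.4-fold higher number from compound 3 to compound 4 (0.14 log units; within the scatter)) and (a 1.7-fold higher number from compound 1 to compound 4 (0.22 log units; within the scatter)), so at this place on the ring nitro cannot be told apart from fluoro or hydrogen, and only the chloro and nitro compounds can be separated from each other. Nothing among the data shown accounts for the gap between these two compounds.

The compounds shown leave open whether an amine, a carboxylic acid or a methoxy group at this same place would stay within the narrow band of these four values or move clearly outside it, in either direction. They also leave open whether the separation between compound 2 and compound 4 would hold on any other cell line.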